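The compounds below may be only part of what the source reports. "The series", "measured", "known", "first", "only" and "open" are said of these compounds alone.

Working notes on the series. Compound 3 `CNC(=O)c1cc(C(=O)NC2CC2)cn(Cc2ccc(C)cc2)c1=O` stands highest of the three numbers in a physicochemical assay for lipophilicity, at pH 7.4 (a lower number here means a more polar compound, a higher number a more lipophilic compound), giving 3.5; its nearest neighbour is compound 1 `CNC(=O)c1cc(C(=O)NC2CC2)cn(Cc2ccc(OC)cc2)c1=O`, which gives 3, and its furthest is compound 2 `CNC(=O)c1cc(C(=O)NC2CC2)cn(Cc2cccc([C@@H](C)O)c2)c1=O`, which gives 2.2. The steps seen so far are a number 0.50 log units higher from compound 1 to compound 3 (beyond the scatter), a number 0.80 log units lower from compound 1 to compound 2 (beyond the scatter) and a number 1.30 log units higher from compound 2 to compound 3 (beyond the scatter).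

The next compound is compound 4 `CNC(=O)c1cc(C(=O)NC2CC2)cn(Cc2cccc3occc23)c1=O`. The change is 1-benzofuran-4-yl in place of 4-methylphenyl on a saturated chain carbon bound to an aromatic nitrogen. Going by the values given here, the steps that bear on it are those at the same place, from compound 1 to compound 2 and from compound 2 to compound 3, both beyond the scatter, the second large; the step from compound 1 to compound 3, modest, is the only one that swaps a methyl for a group carrying one acceptor oxygen. Here the 1-benzofuran-4-yl brings one hydrogen-bond acceptor but also two more heavy atoms, all within a fused aromatic system and with no hydrogen-bond donor, unlike the 3-(1-hydroxyethyl)phenyl of compound 2. The expected step of a number 0.10 log units higher from compound 3 to compound 4 (within the scatter) is therefore small, within the scatter. For compound 4 the estimate in this assay is 3.6, with a range from 3.2 to 4.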

Compound 4, distribution coefficient: 3.4
Compound 4: the middle estimate sits 0.20 log units above what was measured; the measured number falls inside the stated range.
By their numbers in this assay, from the lowest: compound 2; then compound 1; then compounds 4 and 3 (each within the scatter of the next).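

In this assay the step to 1-benzofuran-4-yl on a saturated chain carbon bound to an aromatic nitrogen is a number 0.10 log units lower from compound 3 to compound 4 (within the scatter), so this larger fused group, with its hydrogen-bond acceptor, cannot be told apart from 4-methylphenyl by this read-out. Oxygen in the group does not alone set the number at this place: the steps are a number 1.20 log units higher from compound 2 to compound 4 (beyond the scatter) and a number 0.40 log units higher from compound 1 to compound 4 (beyond the scatter), yet the 1-benzofuran-4-yl of compound 4 carries oxygen, as do the groups of compound 1 and compound 2. Nothing measured here gives a reason for these steps.

From the compounds shown here alone, compound 2 differs from the others in both the group and its attachment pattern, so what its hydroxyl alone contributes stays open. Going by these compounds, how an amine or a carboxylic acid on the aromatic group at this place would read also remains open.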